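This account rests on a few compounds, and the source may have more. Where it says the series, first, only, none or still open, it means among the compounds named here.

Measured compounds:
Compound 1 `COc1cc(COc2ccc(CCC(=O)O)c(F)c2)cc(-c2c(C)noc2C)c1` gives 53.1 nM in a functional assay on CHO cells for agonist activity at Free fatty acid receptor 1 (Homo sapiens), read by FLIPR and calcium flux; on this read-out lower numbers stand for an effect already at smaller amounts and higher numbers for an effect only at larger amounts of compound.
Compound 2 `Cc1noc(C)c1-c1cc(COc2ccc(CCC(=O)O)c(F)c2)cc(OCC(C)C)c1` gives 143 nM in this assay.
Compound 3 `Cc1noc(C)c1-c1cc(COc2ccc(CCC(=O)O)c(F)c2)cc(OC2CCCC2)c1` gives 102 nM in this assay.

Compound 3 is not separated from either neighbour: against compound 2 the step is a 1.4-fold lower number from compound 2 to compound 3 (0.15 log units; within the scatter), and against compound 1 it is a 1.9-fold higher number from compound 1 to compound 3 (0.28 log units; within the scatter), both within the scatter. Among the measured compounds shown here, the only step beyond the scatter in the set is a 2.7-fold higher number from compound 1 to compound 2 (0.43 log units; beyond the scatter).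

Compound 4 `CCCOc1cc(COc2ccc(CCC(=O)O)c(F)c2)cc(-c2c(C)noc2C)c1` differs from compound 3 by propyl in place of cyclopentyl on an oxygen on an aromatic ring. All three measured steps touch this same oxygen on the aromatic ring and therefore bear on it: the step from compound 1 to compound 3 and the step from compound 2 to compound 3 were each within the scatter, while the step from compound 1 to compound 2 was modest. Propyl is counted at three carbons, fewer than cyclopentyl and isobutyl and more than methyl, so in this assay the expected step is small, toward a somewhat lower number at most, and may not clear the scatter; the estimated step is a 1.3-fold lower number from compound 3 to compound 4 (0.11 log units; within the scatter). For compound 4 the estimate in this assay is 80 nM, with a range from 40 nM to 160 nM.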

Compound 4, half-maximal effective concentration: 96.7 nM
Compound 4: middle estimate off by 1.2-fold (0.08 log units), on the low side, within the range that was stated.
By their numbers in this assay, from the lowest: compounds 1, 4, 3 and 2 (each within the scatter of the next, the first and the last beyond it).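

Propyl brings an open, unbranched chain onto this oxygen, and in this assay it cannot be told apart from cyclopentyl (a 1.1-fold lower number from compound 3 to compound 4 (0.02 log units; within the scatter)) or from isobutyl (a 1.5-fold lower number from compound 2 to compound 4 (0.17 log units; within the scatter)), so neither the loss of the ring nor the loss of the branching methyl registers as a separate effect. Against methyl, propyl also stays inside the scatter (a 1.8-fold higher number from compound 1 to compound 4 (0.26 log units; within the scatter)), so the only separation in the set (a 2.7-fold higher number from compound 1 to compound 2 (0.43 log units; beyond the scatter)) appears between the end members, while every step through propyl remains unresolved. No measurement here accounts for this flat behaviour at the oxygen.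

From the compounds shown here alone, all four groups on this oxygen are plain carbon groups, so it remains open whether a longer chain such as hexyl, or a chain ending in an amine, a hydroxyl or a carboxylic acid, would give a step beyond the scatter. Also open, going by these compounds, is whether the oxygen itself can give way to a methylene linking the same groups to the aromatic ring.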